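The source may hold more compounds than are shown below. What is called first, only, known or untested is meant among the compounds shown, and "the series" means these compounds.

Compound 1 `Cc1ccc(-c2ccnc(Nc3ccc4c(c3)c(/C=C3/C(=O)Nc5ccccc53)cn4C)n2)cc1` gives > 100000 nM in a functional assay on LNCaP cells (Homo sapiens) for cytotoxicity, read by MTT assay, with a stated time of 48 h (a higher number here means a weaker inhibitor, a lower number a stronger inhibitor), and that value is a limit of the assay rather than a number.
Compound 2 `COc1ccc(-c2ccnc(Nc3ccc4c(c3)c(/C=C3/C(=O)Nc5ccccc53)cn4C)n2)cc1` gives > 100000 nM in this assay, likewise a limit.
Compound 3 `Cn1cc(/C=C2/C(=O)Nc3ccccc32)c2cc(Nc3nccc(-c4ccc(Cl)cc4)n3)ccc21` gives 6590 nM in this assay.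

Compound 1 stands at the limit of > 100000 nM in this assay, at which 2 of the 3 values shown sit, so its own value in this assay is not a number but a limit, and it shares that position with compound 2. The compound still to be measured is compound 4 `Cn1cc(/C=C2/C(=O)Nc3ccccc32)c2cc(Nc3nccc(-c4ccc(Cl)cc4Cl)n3)ccc21`, which differs from compound 1 by 2,4-dichlorophenyl in place of 4-methylphenyl on an aromatic carbon. The measured steps that bear on this change are an at least 15-fold lower number from compound 1 to compound 3 (1.18 log units; beyond the scatter) and an at least 15-fold lower number from compound 2 to compound 3 (1.18 log units; beyond the scatter), both large and both beyond the scatter; in each case a chloro entering the same aromatic carbon brought the value from the limit down to a number. Compound 4 carries a chloro at that position as well as a second chloro, so in this assay a large downward step is expected, an at least 20-fold lower number from compound 1 to compound 4 (1.30 log units; beyond the scatter), landing close to the value of compound 3. The value of compound 4 is estimated at 5000 nM, with a range from 1500 nM to 20000 nM.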

Compound 4, half-maximal inhibitory concentration: > 100000 nM
Compound 4: a limit, no number (the forecaster's own chance of this, stated with the estimate: 10%); at least 20-fold (1.30 log units) between middle value and limit.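

In this assay, adding a second chloro to the phenyl ring of compound 3 reverses the gain, with an at least 15-fold higher number from compound 3 to compound 4 (1.18 log units; beyond the scatter). A chloro on this ring is therefore not enough on its own to give a measurable value, as the 2,4-dichlorophenyl group of compound 4 returns to a limit, and the steps from compound 1 and from compound 2 to compound 4 cannot be read, with limits at both ends. Compound 3 is now the only compound shown with a number: the limit of > 100000 nM in this assay, at which 3 of the 4 values shown sit.

Within the data shown here, whether a fluoro, a trifluoromethyl or an amine in place of the single chloro of compound 3 would also give a number stays open. Compound 1, compound 2 and compound 4 all carry limits, so their order among themselves is open too.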